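Adding chloro to a compound measured only as a limit

The source may report more compounds than this note shows. Statements on the series, on what has been measured and on what is new or still open speak of the compounds shown alone.

Compound 1 `Cn1cnc(CS(=O)(=O)c2ccccc2)c1[N+](=O)[O-]`: > 888000 nM
Compound 2 `Cn1cnc(CS(=O)(=O)c2ccc(F)cc2)c1[N+](=O)[O-]`: > 835000 nM
Compound 3 `Cc1nc(CS(=O)(=O)c2ccccc2)c([N+](=O)[O-])n1C`: > 846000 nM

In an ADME assay on THP-1 cells (Homo sapiens) for cytotoxicity, read by flow cytometry and propidium iodide staining, with a stated time of 72 h (a higher number here means a weaker inhibitor, a lower number a stronger inhibitor), compound 3 gives > 846000 nM, which is a limit of the assay and not a number. The values of compound 1 and compound 2 are limits as well, so compound 3 cannot be placed in order against either of them.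

The next compound, compound 4 `Cc1nc(CS(=O)(=O)c2ccc(Cl)cc2)c([N+](=O)[O-])n1C`, carries chloro in place of hydrogen on an aromatic carbon, para to a large group: chloro in place of hydrogen on an aromatic carbon. Among the measured compounds shown here, no chloro compound has yet been measured, so two other changes on an aromatic carbon are the nearest guide. Fluoro in place of hydrogen gave a step that the two limits leave unreadable from compound 1 to compound 2. Methyl in place of hydrogen gave a step that the two limits leave unreadable from compound 1 to compound 3.

Neither step offers a size to carry over, and neither shows a direction. A shift beyond the usual scatter is therefore not expected, and compound 4 will probably also end at a limit of this assay. The expected change is an at least 1.1-fold lower number from compound 3 to compound 4 (0.05 log units; that floor lies within the scatter). For compound 4 the estimated value is 750000 nM, with an expected range from 250000 nM to 1000000 nM.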

Compound 4, half-maximal inhibitory concentration: 68000 nM
Compound 4: middle estimate off by 11-fold (1.04 log units), on the high side; measured number below the stated range.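

Phenyl to 4-chlorophenyl is the first change here that brings the read-out down to a measured number: in this assay it gives an at least 12-fold lower number from compound 3 to compound 4 (1.09 log units; beyond the scatter), and compound 4, at 68000 nM, is the only one of the four compounds with a value that is not a limit. The earlier steps shown here, fluoro and methyl in place of hydrogen on an aromatic carbon, cannot be read, so they gave neither a size nor a direction, whereas this change shows that a substituent on the six-membered aromatic ring of carbon only, para to a large group, can move this read-out well beyond the scatter. The step is only a floor, because compound 3 stands at a limit and not at a number: the limit of > 846000 nM in this assay, at which 1 of the 4 values shown sits.

As far as these compounds go, whether chloro would give a similar step on the core of compound 1, without the added methyl, remains open. So does whether the step is particular to chloro, which a bromo, methoxy or trifluoromethyl group at the same place could test.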